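Chloro in place of hydrogen on the shared core

This account rests on a few compounds, and the source may have more. Where it says the series, first, only, none or still open, it means among the compounds named here.

Measured in a functional assay on the whole organism (Hindlimb, strain albino) with Mus musculus as the target, in the maximal electroshock model, with a stated time of 0.5 h; on this read-out lower numbers stand for an effect already at smaller amounts and higher numbers for an effect only at larger amounts of compound:
Compound 1 `COc1ccc(C2CC(Nc3nc4ccc(C)cc4s3)=NN2C(C)=O)cc1`: 37.3 umol/kg
Compound 2 `CC(=O)N1N=C(Nc2nc3ccc(Cl)cc3s2)CC1c1ccccc1`: 161 umol/kg
Compound 3 `COc1ccc(C2CC(Nc3nc4ccccc4s3)=NN2C(C)=O)cc1`: 226 umol/kg

Compound 3 , at 226 umol/kg, stands at the high end of these three numbers. Its value lies within the scatter of that of compound 2 and well away from that of compound 1 . Compound 4 `COc1ccc(C2CC(Nc3nc4ccc(Cl)cc4s3)=NN2C(C)=O)cc1` is compound 3 with chloro in place of hydrogen on an aromatic carbon, and it has yet to be measured in this assay.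

Two measurements bear on this change. Going by the values given here, the only measured single-place step is a 6.1-fold higher number from compound 1 to compound 3 (0.78 log units; beyond the scatter), with hydrogen in place of methyl on an aromatic carbon. Read backwards, it suggests that a group other than hydrogen on that ring may bring a lower number, although methyl is not chloro. Compound 2 already carries chloro but also differs from compound 3 elsewhere, and compound 2 , at 161 umol/kg, shows no separation from compound 3 beyond the scatter. A drop is therefore expected, though a smaller one than the measured step. The expected change is a 2.8-fold lower number from compound 3 to compound 4 (0.45 log units; beyond the scatter). For compound 4 the estimated value is 80 umol/kg, with an expected range of 28 umol/kg to 230 umol/kg.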

Compound 4, dose for half-maximal effect: 93.3 umol/kg
Compound 4: the middle estimate sits 1.2-fold (0.07 log units) below what was measured; low and high end bracket the measured number.
By their numbers in this assay, from the lowest: compound 1; then compounds 4, 2 and 3 (each within the scatter of the next, the first and the last beyond it).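

In this assay, the step of a 2.4-fold lower number from compound 3 to compound 4 (0.38 log units; beyond the scatter) shows that this aromatic carbon responds to chloro as well as to methyl, so the earlier methyl result was not a lone effect of that one group. The step of a 2.5-fold higher number from compound 1 to compound 4 (0.40 log units; beyond the scatter) then separates the two groups at the same place: among hydrogen, chloro and methyl, the numbers fall in that order, and chloro takes the middle, with each of the three steps beyond the scatter. With chloro held on the shared core, the other ring gives a different picture, since a 1.7-fold lower number from compound 2 to compound 4 (0.24 log units; within the scatter) stays within the scatter, so the methoxy group on that other ring has no separable effect in this pair, whereas the same methoxy-bearing series does respond to the change at the chloro position.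

No supporting measurement is available to explain why methyl and chloro differ at this carbon. From the compounds shown here alone, whether a larger or different group there, such as an amine, a fluoro group or a longer chain, would reach or pass the number of compound 1 remains open.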